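A few compounds are considered here, and "the series" means these few. Any claim that something is new, unique, unknown or untested is made for them only; others in the source may bear on it.

Measured compounds:
compound 1 `O=C(N/N=C/c1ccc(Cl)cc1)c1cccnc1Nc1cccc(C(F)(F)F)c1` with 43.7%
compound 2 `COc1ccc(/C=N/NC(=O)c2cccnc2Nc2cccc(C(F)(F)F)c2)cc1` with 14%
compound 3 `CNc1ncccc1C(=O)N/N=C/c1cccc(Cl)c1` with 40.4%

In a functional assay on the whole organism (strain Wistar) for inhibition, with Rattus norvegicus as the target, read by paw edema, with a stated time of 4 h, at a dose of 10 mg/kg by the intraperitoneal route (on this read-out lower numbers stand for less inhibition and higher numbers for more inhibition at the one dose given (going by the name of the read-out)), compound 1 gives 43.7%, while compound 2 gives 14%. The two differ in one place, (methoxy in place of chloro on an aromatic carbon), and the step is a number 29.7 percentage points lower from compound 1 to compound 2 (beyond the scatter). Compound 3 rests on a different core; in this assay compound 3 gives 40.4%, and the difference between the two cores is not broken down here. Compound 4 `CNc1ncccc1C(=O)N/N=C/c1cccc(OC)c1` has not been measured. It differs from compound 3 by methoxy in place of chloro on an aromatic carbon, the same kind of change as that from compound 1 to compound 2, though here the group sits meta to a large group rather than para to it. Resting on the step of a number 29.7 percentage points lower from compound 1 to compound 2 (beyond the scatter), a drop of similar size is expected, a number 24.4 percentage points lower from compound 3 to compound 4 (beyond the scatter), so compound 4 is estimated at 16%, between 2% and 34%.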

Compound 4, a percentage reported as inhibition, in the whole organism at one dose (the size of the read-out at that dose, not a potency): 42.3%
Estimate against measurement, compound 4: 26.3 percentage points below, and the stated range ends below it.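

In this assay, putting methoxy in place of chloro on the core of compound 3 gives a number 1.9 percentage points higher from compound 3 to compound 4 (within the scatter), so on these two cores the change does not carry over with a fixed size. The two steps set side by side differ: the same change on two cores in this assay, a number 29.7 percentage points lower (beyond the scatter) from compound 1 to compound 2 and a number 1.9 percentage points higher (within the scatter) from compound 3 to compound 4, 31.6 percentage points apart, beyond the scatter of two such steps. This does not show whether the core itself or the place of the group on the aromatic ring sets that gap, since the two pairs differ in both, and one pair on each core gives no rule for any other core.

The compounds shown leave open how an amine or a carboxylic acid at the same aromatic carbon would read on either core. They also leave open whether chloro and methoxy would separate on the core of compound 3 with the group placed as in compound 1.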